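This account rests on a few compounds, and the source may have more. Where it says the series, first, only, none or still open, it means among the compounds named here.

Notes on the series. Compound 1 `Cn1cncc1CN1CC(N(CC2CCN(C(=O)c3ccccc3)CC2)S(=O)(=O)c2ccccn2)Cc2cc(C#N)ccc21` carries a benzoyl group on the amine nitrogen of the outer ring; in an ADME assay on Caco-2 cells (Homo sapiens) for permeability, in the apical to basolateral direction (on this read-out higher numbers stand for higher permeability and lower numbers for lower permeability), compound 1 gives 0.5 10^-6 cm/s. Compound 2 `CCS(=O)(=O)N1CCC(CN(C2Cc3cc(C#N)ccc3N(Cc3cncn3C)C2)S(=O)(=O)c2ccccn2)CC1` gives 0.1 10^-6 cm/s, and compound 3 `Cn1cncc1CN1CC(N(CC2CCN(S(C)(=O)=O)CC2)S(=O)(=O)c2ccccn2)Cc2cc(C#N)ccc21` gives 0.1 10^-6 cm/s. Compound 1 stands highest of the three numbers: a 5.0-fold lower number from compound 1 to compound 2 (0.70 log units; beyond the scatter), and a 5.0-fold lower number from compound 1 to compound 3 (0.70 log units; beyond the scatter), each a modest step beyond the scatter. Between the two sulfonyl analogues there is no change at the digits printed from compound 2 to compound 3 (within the scatter).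

Compound 4 `Cn1cncc1CN1CC(N(CC2CCN(C(=O)N3CCCCC3)CC2)S(=O)(=O)c2ccccn2)Cc2cc(C#N)ccc21` differs from compound 1 at the same carbonyl: piperidin-1-yl in place of phenyl on a carbonyl carbon. For the measured compounds named here, no measured step covers this exact change; the two steps that touch the same position both trade benzoyl for a sulfonyl and both lower the number by the same modest amount. That the carbonyl is kept in compound 4 argues for a smaller movement than either of those, so a step of a 1.7-fold lower number from compound 1 to compound 4 (0.22 log units; within the scatter) is expected, downward, with a fair chance it stays within the scatter. Compound 4 is therefore estimated at 0.3 10^-6 cm/s, ranging from 0.1 10^-6 cm/s to 0.8 10^-6 cm/s.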

Compound 4, apparent permeability: 0.6 10^-6 cm/s
Compound 4: the middle estimate sits 2.0-fold (0.30 log units) below what was measured; the measured number falls inside the stated range.
By their numbers in this assay, from the lowest: compounds 2 and 3 (each within the scatter of the next); then compounds 1 and 4 (each within the scatter of the next).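

In this assay, phenyl and piperidin-1-yl on the carbonyl carbon read alike, with a 1.2-fold higher number from compound 1 to compound 4 (0.08 log units; within the scatter), so an aromatic ring of carbon only is not needed at this place to keep the number. The gap to the sulfonyl compounds, earlier seen only with benzoyl, also appears with (piperidin-1-yl)carbonyl, with a 6.0-fold higher number from compound 3 to compound 4 (0.78 log units; beyond the scatter) and a 6.0-fold higher number from compound 2 to compound 4 (0.78 log units; beyond the scatter); among these four compounds, both carbonyl-linked groups stand above both sulfonyl groups. Nothing on hand explains this gap.

Still open, on these data alone, is whether a methyl or dimethylamino group on the same carbonyl carbon keeps the number level with compound 1 and compound 4. Also open, as far as these compounds go, is whether a phenylsulfonyl group on the amine nitrogen in the ring stays level with compound 2 and compound 3.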